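The compounds below may be only part of what the source reports. "The series", "measured", "known", "first", "only" and "open" are said of these compounds alone.

Measured compounds:
- Compound 1, `CCOc1ccc(/C=C(\C(=O)c2ccc(Cl)cc2)S(=O)(=O)Cc2ccc(F)cc2)cc1OC`: 50000 nM
- Compound 2, `CCOc1ccc(/C=C(\C(=O)c2ccc(Cl)cc2)S(=O)(=O)c2ccc(C)cc2)cc1OC`: 1000 nM
- Compound 3, `CCOc1ccc(/C=C(/Sc2ccccc2Cl)C(=O)c2ccc(Cl)cc2)cc1OC`: 50000 nM

All three were tested in a functional assay on DU-145 cells (Homo sapiens) for inhibition, read by trypan blue exclusion, with a stated time of 96 h; on this read-out lower numbers stand for stronger inhibition of growth and higher numbers for weaker inhibition of growth. Compound 1 stands level with compound 3 at the digits given, and together they carry the highest numbers of the three, meaning the weakest growth inhibition. Among the measured compounds shown here, the only strong step among the measured compounds is a 50-fold lower number from compound 1 to compound 2 (1.70 log units; beyond the scatter), where the group on the sulfonyl sulfur was changed; the related step of a 50-fold higher number from compound 2 to compound 3 (1.70 log units; beyond the scatter) runs the other way, and no change at the digits printed from compound 1 to compound 3 (within the scatter) shows no change.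

Compound 4, `O=C(/C(=C\c1c[nH]c2ccccc12)S(=O)(=O)Cc1ccc(F)cc1)c1ccc(Cl)cc1`, differs from compound 1 elsewhere: 1H-indol-3-yl in place of 4-ethoxy-3-methoxyphenyl on a double-bonded chain carbon bound to a double-bonded chain carbon. For the measured compounds named here, none of the measured steps touches this part of the molecule; every step so far alters the sulfur-bearing group, while the aryl on the double bond is kept. Going by the values given here, there is therefore no measured step that bears directly on this change, and no basis for expecting a move beyond the scatter in either direction. The expectation for compound 4 is accordingly an inhibition close to that of compound 1, with the step of a 1.3-fold lower number from compound 1 to compound 4 (0.10 log units; within the scatter) estimated as small. Compound 4 is estimated at 40000 nM, within a range of 10000 nM to 50000 nM, with compound 1 at 50000 nM as the anchor.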

Compound 4, concentration for 50% growth inhibition: 50000 nM
Beside the measured number, compound 4's estimate is 1.3-fold (0.10 log units) below it, and the stated range covers the measured number.
By their numbers in this assay, from the lowest: compound 2; then compounds 1, 3 and 4 (each within the scatter of the next).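

In this assay, this is the first change shown to the aryl group on the double-bonded chain carbon, and it reads as no change at the digits printed from compound 1 to compound 4 (within the scatter). With the (4-fluorobenzyl)sulfonyl group held fixed, 1H-indol-3-yl and 4-ethoxy-3-methoxyphenyl therefore give the same reading at this place, although the first brings a five-membered aromatic ring and a hydrogen-bond donor and the second has neither, so in this pair the growth reading does not follow those differences in the group. No measurement shown gives a reason for this outcome.

Among the compounds shown here, both compounds carry the 4-fluorobenzyl group and sit with compound 3 at the high end of the numbers, so a flat step here cannot say what 1H-indol-3-yl would do alongside the 4-methylphenyl group of compound 2, the one compound with a clearly lower number. Also open, on these data alone, is how this place would respond to a group of a different kind, such as a phenyl ring bearing an amine or a carboxylic acid, or a pyridine ring.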